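This account rests on a few compounds, and the source may have more. Where it says the series, first, only, none or still open, it means among the compounds named here.

In a functional assay on L1210 cells (Mus musculus) for inhibition, read by MTT assay, with a stated time of 72 h (on this read-out higher numbers stand for weaker inhibition and lower numbers for stronger inhibition), compound 1 (`COc1cc(NC(C)CCCNC(=O)NNC(=O)Nc2ccc(Cl)cc2)c2ncccc2c1`) gives 58000 nM. In this assay, compound 2 (`COc1cc(NC(C)CCCNC(=O)NNC(=O)Nc2cccc(F)c2)c2ncccc2c1`) gives 108000 nM, and so the two numbers lie within the scatter of each other and neither can be ranked above the other. Compound 3 (`COc1cc(NC(C)CCCNC(=O)NNC(=O)Nc2cccc(C(F)(F)F)c2)c2ncccc2c1`) shares its core with compound 2 and carries trifluoromethyl in place of fluoro on an aromatic carbon, meta to a large group: trifluoromethyl in place of fluoro on an aromatic carbon. Going by the values given here, only one measured step bears on this change, and only indirectly: a 1.9-fold higher number from compound 1 to compound 2 (0.27 log units; within the scatter), which puts 3-fluorophenyl in place of 4-chlorophenyl on an amide-type nitrogen. That step does not leave the scatter. Among the compounds with values here, no measured compound carries trifluoromethyl, so the data do not show how this group behaves here. Within the data shown here, with only this small step as a guide, no change beyond the scatter is expected in this assay, and any shift is expected to be modest. The estimated change is a 1.4-fold lower number from compound 2 to compound 3 (0.16 log units; within the scatter). For compound 3 the expected value is 75000 nM, with an estimated range from 30000 nM to 170000 nM.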

Compound 3, half-maximal inhibitory concentration: 4000 nM
The estimate for compound 3 lay 19-fold (1.27 log units) above the measured number; measured number below the stated range.
By their numbers in this assay, from the lowest: compound 3; then compounds 1 and 2 (each within the scatter of the next).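

In this assay, going by these compounds alone, the change from fluoro to trifluoromethyl on an aromatic carbon, meta to a large group, gives a 27-fold lower number from compound 2 to compound 3 (1.43 log units; beyond the scatter) and is the first step to leave the scatter. The comparison with the 4-chlorophenyl compound points the same way, with a 15-fold lower number from compound 1 to compound 3 (1.16 log units; beyond the scatter), so 3-(trifluoromethyl)phenyl stands apart from both other aryl groups, although the step between those two stayed within the scatter and had suggested that this part of the molecule mattered little to the read-out. No measured property is available to account for this large step.

The compounds shown leave open whether a methyl, a methoxy or a nitrile on the same aromatic carbon would give a number close to that of compound 3 or stay with compounds 1 and 2, and whether trifluoromethyl would do the same on another carbon of the ring. They also leave open whether the lower number would persist with a longer chain in place of the present one or with a free amine on that chain.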